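The compounds below may be only part of what the source reports. "The series", "measured", "known", "first", "only" and "open" are said of these compounds alone.

In an ADME assay on the whole organism (Rattus norvegicus, strain Sprague-Dawley) for pharmacokinetics, using cassette dosing, at a dose of 0.5 mg/kg by the intravenous route (a lower number here means slower removal, a higher number faster removal of the compound), three compounds sharing one core have been measured so far. Compound 1, `O=C(Nc1ccc2[nH]c(=O)oc2c1)C(=O)N1CCN(c2ccc(Cl)cc2)CC1`, gives 7.2 mL/min/kg. Compound 2, `O=C(Nc1ccc2[nH]c(=O)oc2c1)C(=O)N1CCN(c2ccc(F)cc2)CC1`, gives 11.1 mL/min/kg. Compound 3, `C[C@@H]1CN(c2ccc(F)c(F)c2)CCN1C(=O)C(=O)Nc1ccc2[nH]c(=O)oc2c1`, gives 5.6 mL/min/kg. Compound 1 and compound 2 differ in a single place: chloro in place of fluoro on an aromatic carbon. That change made a 1.5-fold lower number from compound 2 to compound 1 (0.19 log units; within the scatter), a step that stays inside the usual scatter of such measurements, so the two numbers cannot be told apart with confidence. The cores of compound 2 and compound 3 differ in more than one place, and the difference between them is not broken down here; what can be said is that compound 3 gives the lowest of the three numbers, yet each gap to the others lies within the scatter.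

Compound 4, `C[C@@H]1CN(c2ccc(Cl)c(F)c2)CCN1C(=O)C(=O)Nc1ccc2[nH]c(=O)oc2c1`, has not yet been measured. It differs from compound 3 in one place: chloro in place of fluoro on an aromatic carbon. For the measured compounds named here, this is the same kind of change as the one from compound 2 to compound 1, but not the same: in compound 4 the new chloro sits ortho to a fluoro group, whereas in compound 1 the place is only para to a large group. Because compound 2 to compound 1 gave a 1.5-fold lower number from compound 2 to compound 1 (0.19 log units; within the scatter), a similarly small step is expected here, so that the step from compound 3 to compound 4 is estimated at a 1.2-fold lower number from compound 3 to compound 4 (0.09 log units; within the scatter). Compound 4 is therefore expected to give about 4.5 mL/min/kg, most likely between 2.5 mL/min/kg and 8.5 mL/min/kg.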

Compound 4, clearance: 1.37 mL/min/kg
Estimate against measurement, compound 4: 3.3-fold (0.52 log units) above; the measured number lies below the stated range.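

In this assay, putting chloro in place of fluoro on an aromatic carbon gave a 4.1-fold lower number from compound 3 to compound 4 (0.61 log units; beyond the scatter), a step that stands clear of the usual spread of repeated measurements, unlike the earlier step on the other core. Set side by side, the two steps cannot be told apart, so the data fit a single change behaving alike on both cores, with the apparent gap between the steps possibly being no more than measurement noise: the same change on two cores in this assay, a 1.5-fold lower number (0.19 log units; within the scatter) from compound 2 to compound 1 and a 4.1-fold lower number (0.61 log units; beyond the scatter) from compound 3 to compound 4, 2.7-fold (0.42 log units) apart, within the scatter of two such steps What this does not show is that the change lowers the number on every core in the series, since only two cores are on hand and only one of the two steps is clear of the scatter on its own, and it gives no reason for the result.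

The compounds shown leave open whether another group in the same place, such as bromo, methyl, trifluoromethyl or a nitrile, would give a number close to that of compound 4, at 1.37 mL/min/kg, or a quite different one. They also leave open whether that low number would hold up if compound 4 were dosed alone rather than in a cassette.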